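The compounds below may be only part of what the source reports. "The series", "measured", "known", "first", "only" and "open" are said of these compounds alone.

Measured compounds:
- compound 1, `Nc1scc(CN2CCN(c3cc(Cl)cc(Cl)c3)CC2)c1C(=O)c1ccc(Cl)cc1`: 1%
- compound 2, `Nc1scc(CN2CCN(c3ccc(Cl)c(C(F)(F)F)c3)CC2)c1C(=O)c1ccc(Cl)cc1`: 3%
- compound 3, `Nc1scc(CN2CCN(c3ccc(F)c(F)c3)CC2)c1C(=O)c1ccc(Cl)cc1`: 1%

In an assay on CHO cells for displacement of a labelled ligand from adenosine receptor A3 (Homo sapiens), read by scintillation counting, with a stated time of 120 min, tested at 10 uM (a lower number here means less inhibition, a higher number more inhibition at the concentration tested (going by the name of the read-out)), compound 1 gives 1%, compound 2 gives 3% and compound 3 gives 1%. Compound 3 stands level with compound 1, with no change at the digits printed from compound 1 to compound 3 (within the scatter), and its widest gap is to compound 2, with a number 2 percentage points lower from compound 2 to compound 3 (within the scatter); every gap among the three is within the scatter, so none of the three can be set apart from the others on these numbers.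

Compound 4, `Nc1scc(CN2CCN(c3c(F)cc(F)cc3F)CC2)c1C(=O)c1ccc(Cl)cc1`, is not yet measured. It differs from compound 3 by 2,4,6-trifluorophenyl in place of 3,4-difluorophenyl on an amine nitrogen in a ring. The three measured steps all exchange the aryl group on the same ring amine nitrogen, and all three were within the scatter: a number 2 percentage points higher from compound 1 to compound 2 (within the scatter), no change at the digits printed from compound 1 to compound 3 (within the scatter) and a number 2 percentage points lower from compound 2 to compound 3 (within the scatter). Compound 4 exchanges that same group once more, so the expectation is a step of no size beyond the scatter, a number 1 percentage points higher from compound 3 to compound 4 (within the scatter), with no direction to favour. Compound 4 is therefore expected to give about 2% in this assay, with a range from 0% to 10%.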

Compound 4, a percentage reported as inhibition, at one concentration (the size of the read-out at that concentration, not a potency): 0%
Compound 4: the middle estimate sits 2 percentage points above what was measured; the measured number falls inside the stated range.
By their numbers in this assay, from the lowest: compounds 4, 1, 3 and 2 (each within the scatter of the next).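

In this assay, the 2,4,6-trifluorophenyl group brings a fourth aryl group to the amine nitrogen in the ring, and the result is a number 1 percentage points lower from compound 3 to compound 4 (within the scatter) and a number 3 percentage points lower from compound 2 to compound 4 (within the scatter) and a number 1 percentage points lower from compound 1 to compound 4 (within the scatter). Until now the aryl groups at this place carried two or three halogen-bearing substituents of mixed kinds, and none carried three fluorines; with this group, which has 9 heavy atoms against 8 for 3,4-difluorophenyl, compound 4 gives 0%, so it cannot be set apart from any of the other three compounds, and this place has still shown no measurable response to a change of aryl group. No measurement is at hand that would account for these numbers.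

From the compounds shown here alone, all four compounds carry a halogenated phenyl group on that nitrogen, so it stays open whether a group of another kind there, such as a pyridine ring, a phenyl ring bearing a carboxylic acid or an amine, or a simple benzyl group, would move the number beyond the scatter. Going by these compounds, it also stays open whether any change to the rest of the shared core, such as replacing the 4-chlorophenyl group on the carbonyl, would do so.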